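Lengthening the chain on compound 3

The source may report more compounds than this note shows. Statements on the series, on what has been measured and on what is new or still open speak of the compounds shown alone.

Measured in a functional assay on HCT-116 cells (Homo sapiens) for antiproliferative activity, read by MTT assay, with a stated time of 48 h; a lower number here means a stronger inhibitor, a higher number a weaker inhibitor:
- compound 1 `CCCCCC(CCO)n1cnc2c(Cl)ncnc21` gives > 50000 nM (a limit)
- compound 2 `CCCCCC(CCO)n1cnc2c(OC)ncnc21` gives > 50000 nM (a limit)
- compound 3 `CCCCCC(CCO)n1cnc2c(N(C)C)ncnc21` gives > 50000 nM (a limit)

Compound 3 stands at > 50000 nM as a limit, with no number to step from. The series as a whole shows the limit of > 50000 nM in this assay, at which 3 of the 3 values shown sit, and nothing more. Compound 4 `CCCCCCCCCCC(CCO)n1cnc2c(N(C)C)ncnc21` brings the change pentyl in place of hydrogen on a saturated chain carbon, six bonds along the chain from an aromatic nitrogen (read another way, propyl to octyl). The measured steps a step that the two limits leave unreadable from compound 1 to compound 2 and a step that the two limits leave unreadable from compound 1 to compound 3 and a step that the two limits leave unreadable from compound 2 to compound 3 all swap the group on an aromatic carbon, leave the chain untouched and give no size for this change. With compound 3 at its limit, only a step toward stronger inhibition could be read in this assay and a modest one is expected. The expected size is an at least 1.6-fold lower number from compound 3 to compound 4 (0.22 log units; that floor lies within the scatter) in this estimate. For compound 4 the estimated value is 30000 nM within a range from 10000 nM to 60000 nM and a limit in place of a number remains possible.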

Compound 4, half-maximal inhibitory concentration: 5490 nM
Estimate against measurement, compound 4: 5.5-fold (0.74 log units) above, outside the stated range (below it).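

Pentyl in place of hydrogen on this saturated chain carbon gives an at least 9.1-fold lower number from compound 3 to compound 4 (0.95 log units; beyond the scatter) in this assay, so the chain at this position can move the series off its limit. The steps among compound 1, compound 2 and compound 3 cannot be read, which leaves the swaps on the aromatic carbon without a size. Compound 4 is the only compound here with a number rather than a limit: the limit of > 50000 nM in this assay, at which 3 of the 4 values shown sit.

Going by these compounds, the full size of the step stays open, since compound 3 has only a limit. Also open, on these data alone, are whether a longer chain goes further and whether chloro or methoxy in place of dimethylamino keeps the gain on this chain.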